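This account rests on a few compounds, and the source may have more. Where it says the series, first, only, none or still open, it means among the compounds named here.

The series shares one core, seen in compound 1 `Nc1sc(-c2ccc(Cl)cc2)c(-c2ccc(Cl)cc2)c1C(=O)NC1CCCCC1`, which in a functional assay on A549 cells (Homo sapiens) for inhibition, read by sulforhodamine B assay, with a stated time of 72 h (on this read-out lower numbers stand for stronger inhibition and higher numbers for weaker inhibition), gives 2410 nM. Within the data shown here, compound 2 `Nc1sc(-c2ccc(Cl)cc2)c(-c2ccc(Cl)cc2)c1C(=O)Nc1ccccc1` carries a phenyl on the same amide-type nitrogen and in this assay gives 25000 nM, the highest of the two numbers recorded; the only measured step, a 10-fold higher number from compound 1 to compound 2 (1.02 log units; beyond the scatter), is the step that separates them. Compound 3 `CCN(CC)CCNC(=O)Nc1sc(-c2ccc(Cl)cc2)c(-c2ccc(Cl)cc2)c1C(=O)NC1CC1` belongs to the same set, but in this assay compound 3 stands as "not determined" (no result reported), so no number is available for it.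

Compound 4 `COc1ccc(CNC(=O)c2c(N)sc(-c3ccc(Cl)cc3)c2-c2ccc(Cl)cc2)cc1` differs from compound 2 at that nitrogen: 4-methoxybenzyl in place of phenyl on an amide-type nitrogen. Among the measured compounds shown here, no measured step covers this exact change. For the measured compounds named here, the one step that bears on it, from compound 1 to compound 2, shows that the group on this nitrogen can move the number by a large amount, and a phenyl gave the weaker result. A 4-methoxybenzyl is neither the phenyl of compound 2 nor the cyclohexyl of compound 1, so a lower number than compound 2 is expected, though short of compound 1, giving an expected step of a 3.6-fold lower number from compound 2 to compound 4 (0.55 log units; beyond the scatter). Compound 4 is therefore estimated at 7000 nM, within a range of 1800 nM to 27000 nM.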

Compound 4, half-maximal inhibitory concentration: 18200 nM
Estimate against measurement, compound 4: 2.6-fold (0.41 log units) below, within the range that was stated.
By their numbers in this assay, from the lowest: compound 1; then compounds 4 and 2 (each within the scatter of the next).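

In this assay, a 1.4-fold lower number from compound 2 to compound 4 (0.14 log units; within the scatter) lies within the scatter, so on this amide-type nitrogen the 4-methoxybenzyl cannot be told apart from the phenyl, even though it brings more heavy atoms and a hydrogen-bond acceptor. By contrast, a 7.6-fold higher number from compound 1 to compound 4 (0.88 log units; beyond the scatter) lies beyond the scatter, so the cyclohexyl of compound 1 now stands apart from two different groups that each carry an aromatic ring, not from the phenyl alone. Nothing available gives a reason for this difference.

On these data alone, it remains open whether the lower number of compound 1 extends to a cyclopentyl ring or a hexyl chain on this nitrogen. Also open, as far as these compounds go, is whether a carboxylic acid or an amine on the benzyl ring would move the number at all.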